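The source may hold more compounds than are shown below. What is called first, only, known or untested is meant among the compounds shown, and "the series" means these compounds.

- Compound 1 `CC(C)CNC(=O)n1c(=O)oc2cc(C3CCN(C)CC3)ccc21`: 1.33 h
- Compound 2 `CN1CCC(c2ccc3c(c2)oc(=O)n3C(=O)NCCCCc2ccccc2)CC1`: 0.833 h

Both compounds were measured in an ADME assay on a cell-free system (plasma, Mus musculus) for metabolic stability, read by LC-MS, tested at 2 uM (on this read-out lower numbers stand for a shorter-lived compound and higher numbers for a longer-lived compound), and compound 2, at 0.833 h, stands within the usual scatter of compound 1. Compound 3 `CCCCCNC(=O)n1c(=O)oc2cc(C3CCN(C)CC3)ccc21` differs from compound 2 by one change: methyl in place of phenyl on a saturated chain carbon, four bonds along the chain from an amide-type nitrogen. In words, this is methyl in place of phenyl on a saturated chain carbon, four bonds along the chain from an amide-type nitrogen. Going by the values given here, the one measured step on this side chain is small: a 1.6-fold lower number from compound 1 to compound 2 (0.20 log units; within the scatter). No step beyond the scatter is therefore expected in this assay. The estimated step is a 1.3-fold higher number from compound 2 to compound 3 (0.12 log units; within the scatter). Compound 3 is expected at 1.1 h, with an estimated range of 0.55 h to 2.2 h.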

Compound 3, half-life: 1.25 h
Compound 3: the middle estimate sits 1.1-fold (0.06 log units) below what was measured, within the range that was stated.
By their numbers in this assay, from the lowest: compounds 2, 3 and 1 (each within the scatter of the next).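

In this assay, methyl in place of phenyl at the end of the chain gives a 1.5-fold higher number from compound 2 to compound 3 (0.18 log units; within the scatter), so this position tolerates losing the aromatic ring without a step beyond the scatter. Butyl in place of isopropyl gives a 1.1-fold lower number from compound 1 to compound 3 (0.03 log units; within the scatter), so the straight and branched chains also cannot be told apart here. No supporting measurement explains these numbers. Still open, as far as these compounds go, is whether a side chain ending in an amine or a carboxylic acid would stay within the scatter of these three compounds.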